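Carbamoyl substituent variation on the shared core

A few compounds are considered here, and "the series" means these few. Any claim that something is new, unique, unknown or untested is made for them only; others in the source may bear on it.

Measured compounds:
compound 1, `CC(C)(C)C(=O)N1CCC[C@H]1C(=O)N1CCC(NS(=O)(=O)c2cc(S(=O)(=O)c3ccccc3)ccc2C(F)(F)F)CC1` — in an assay on isolated protein for binding affinity to secreted frizzled-related protein 1 (Homo sapiens), read by fluorescence (a higher number here means a weaker inhibitor, a lower number a stronger inhibitor), compound 1 gives 40 nM
compound 2, `CCNC(=O)N1CCC[C@H]1C(=O)N1CCC(NS(=O)(=O)c2cc(S(=O)(=O)c3ccccc3)ccc2C(F)(F)F)CC1` — in this assay compound 2 gives 30 nM
compound 3, `CC(C)(C)NC(=O)N1CCC[C@H]1C(=O)N1CCC(NS(=O)(=O)c2cc(S(=O)(=O)c3ccccc3)ccc2C(F)(F)F)CC1` — in this assay compound 3 gives 20 nM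

Compound 3 stands lowest of the three numbers, but its separation from the others is small: a 1.5-fold lower number from compound 2 to compound 3 (0.18 log units; within the scatter) and a 2.0-fold lower number from compound 1 to compound 3 (0.30 log units; within the scatter), both within the scatter, so no ordering among compounds 1, 2 and 3 can be claimed.

Compound 4, `O=C([C@@H]1CCCN1C(=O)Nc1ccccc1)N1CCC(NS(=O)(=O)c2cc(S(=O)(=O)c3ccccc3)ccc2C(F)(F)F)CC1`, is still to be measured in this assay. Its difference from compound 3 is phenyl in place of tert-butyl on an amide-type nitrogen.

Going by the values given here, the steps that bear on it are those altering the group on the carbonyl carbon or on the amide-type nitrogen: a 1.3-fold lower number from compound 1 to compound 2 (0.12 log units; within the scatter), a 2.0-fold lower number from compound 1 to compound 3 (0.30 log units; within the scatter) and a 1.5-fold lower number from compound 2 to compound 3 (0.18 log units; within the scatter). None moved the number beyond the scatter, whether a tert-butyl was swapped for ethylamino or (tert-butyl)amino, or ethyl for tert-butyl on the nitrogen. On these data alone, a phenyl at that position is untested, so the expectation rests on the indifference seen so far.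

For compound 4 the expected step in this assay is a 1.1-fold higher number from compound 3 to compound 4 (0.04 log units; within the scatter), i.e. none beyond the scatter. Compound 4 is estimated at 22 nM, with a range from 8 nM to 60 nM.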

Compound 4, half-maximal inhibitory concentration in the secreted frizzled-related protein 1 assay: 20 nM
Estimate against measurement, compound 4: 1.1-fold (0.04 log units) above; the range from low to high includes it.
By their numbers in the secreted frizzled-related protein 1 assay, from the lowest: compounds 3, 4, 2 and 1 (each within the scatter of the next).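

Going by these compounds alone, in the secreted frizzled-related protein 1 assay the amide-type nitrogen accepts a six-membered aromatic ring as readily as an alkyl group: phenyl in place of tert-butyl gives no change at the digits printed from compound 3 to compound 4 (within the scatter) and phenyl in place of ethyl gives a 1.5-fold lower number from compound 2 to compound 4 (0.18 log units; within the scatter) while anilino in place of tert-butyl on the carbonyl carbon gives a 2.0-fold lower number from compound 1 to compound 4 (0.30 log units; within the scatter) and so the insensitivity seen among the earlier compounds now extends to an aromatic group. In a physicochemical assay for solubility (a lower number here means a less soluble compound, a higher number a more soluble compound), the phenyl for tert-butyl change gives a 2.0-fold lower number from compound 3 to compound 4 (0.30 log units; within the scatter) with compound 3 at 50000 nM and compound 4 at 25000 nM so this read-out does not separate the two beyond the scatter either. Nothing available explains this tolerance at the position.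

Tert-butyl and phenyl both count no hydrogen-bond donors or acceptors, so it remains open whether a group carrying an amine or a carboxylic acid on this nitrogen would stay within the scatter of compound 3. Also open, on these data alone, is whether a pyridine ring, a phenyl bearing a substituent or a longer chain such as benzyl would keep the number in the secreted frizzled-related protein 1 assay where compound 3 and compound 4 stand.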